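The source may hold more compounds than are shown below. What is called first, only, known or untested is meant among the compounds shown, and "the series" means these compounds.

Compound 1 `CC(=O)O[C@H]1C[C@@H](C)C=C2C=C[C@H](C)[C@H](CC[C@@H]3C[C@@H](O)CC(=O)O3)C21` carries an acetyl ester on its core, and in an assay for inhibition of 3-hydroxy-3-methylglutaryl-coenzyme A reductase (Rattus norvegicus) (a higher number here means a weaker inhibitor, a lower number a stronger inhibitor), compound 1 gives 269 nM. Compound 2 `CCCCC(=O)O[C@H]1C[C@@H](C)C=C2C=C[C@H](C)[C@H](CC[C@@H]3C[C@@H](O)CC(=O)O3)C21` differs only at the ester, and in this assay compound 2 gives 8.7 nM. The step of a 31-fold lower number from compound 1 to compound 2 (1.49 log units; beyond the scatter) is the only measured one, and it leaves compound 2 with the lowest of the two numbers, its nearest neighbour being compound 1.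

Compound 3 `CC(C)CC(=O)O[C@H]1C[C@@H](C)C=C2C=C[C@H](C)[C@H](CC[C@@H]3C[C@@H](O)CC(=O)O3)C21` is the next point. The change isopropyl in place of propyl on a saturated chain carbon bound to a carbonyl carbon keeps every atom of compound 2 and only rearranges the chain. The measured step of a 31-fold lower number from compound 1 to compound 2 (1.49 log units; beyond the scatter) bears on the same place, but it added three carbons, whereas this step adds none. For the measured compounds named here, no measured pair shows what branching alone does here, so for compound 3 a step of a 1.4-fold higher number from compound 2 to compound 3 (0.14 log units; within the scatter) that stays within the scatter is expected, with the branched chain read as roughly equal to the straight one. Compound 3 is therefore estimated at 12 nM in this assay, within a range from 4 nM to 35 nM.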

Compound 3, half-maximal inhibitory concentration: 5.4 nM
Compound 3: middle estimate off by 2.2-fold (0.35 log units), on the high side; low and high end bracket the measured number.
By their numbers in this assay, from the lowest: compounds 3 and 2 (each within the scatter of the next); then compound 1.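

In this assay, the step of a 1.6-fold lower number from compound 2 to compound 3 (0.21 log units; within the scatter) shows that the same carbons, joined as isopropyl rather than propyl on this saturated chain carbon bound to a carbonyl carbon, give numbers that cannot be told apart, so this branching leaves the result of the longer ester intact. The step of a 50-fold lower number from compound 1 to compound 3 (1.70 log units; beyond the scatter), like a 31-fold lower number from compound 1 to compound 2 (1.49 log units; beyond the scatter), lies beyond the scatter, which means the large difference from the acetyl ester of compound 1 now rests on two differently joined chains rather than on the straight chain alone. No supporting evidence accompanies these numbers that would explain how the chains produce this difference.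

The compounds shown leave open how the number behaves between the hydrogen of compound 1 and the propyl of compound 2, where an ethyl or methyl group would fill the gap, and whether a longer chain such as hexyl would continue the trend or reverse it. They also leave open whether a phenyl ring, an amine or a carboxylic acid at this place would be tolerated as well as the two chains.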